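Extending the Methoxy Chain of Compound 2

The source may report more compounds than this note shows. Statements on the series, on what has been measured and on what is new or still open speak of the compounds shown alone.

Compound 2 `COc1cc(NC(=O)c2cnc(C)cn2)c2ncccc2c1` gives the lowest number of the three measured compounds in a functional assay on PANC-1 cells (Homo sapiens) for inhibition, read by MTT assay, with a stated time of 72 h (a lower number here means a stronger inhibitor, a higher number a weaker inhibitor), namely 800 nM. Compound 1 `Cc1cnc(C(=O)Nc2cc(F)cc3cccnc23)cn1` gives 2100 nM in this assay, and the move from fluoro to methoxy gives a 2.6-fold lower number from compound 1 to compound 2 (0.42 log units; beyond the scatter). Compound 3 `COc1cc(NC(=O)c2cnccn2)c2ncccc2c1` gives 2170 nM, the change being a 2.7-fold higher number from compound 2 to compound 3 (0.43 log units; beyond the scatter). Compound 4 `Cc1cnc(C(=O)Nc2cc(OCCN)cc3cccnc23)cn1` differs from compound 2 by aminomethyl in place of hydrogen on a saturated chain carbon bound to an oxygen on an aromatic ring. Neither measured step touches this chain, so no direct guide exists; both steps show only modest shifts from single changes on the core. A similarly modest step, or none beyond the scatter, is therefore expected, with the direction uncertain. Compound 4 is estimated at 1000 nM, within 300 nM to 3500 nM, which means an expected 1.3-fold higher number from compound 2 to compound 4 (0.10 log units; within the scatter).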

Compound 4, half-maximal inhibitory concentration: > 10000 nM
Compound 4 gave a limit, no number; the forecaster's own chance of this, stated with the estimate: 3%; at least 10-fold (1.00 log units) between middle value and limit.
By their numbers in this assay, from the lowest: compound 2; then compounds 1 and 3 (each within the scatter of the next). At a limit, above all of these: compound 4.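

Compound 4 gave only a limit of the assay, not a number: the limit of > 10000 nM in this assay, at which 1 of the 4 values shown sits.

So the methoxy position is not indifferent to what is built onto it: in this assay, extending methoxy to 2-aminoethoxy brings an at least 12-fold higher number from compound 2 to compound 4 (1.09 log units; beyond the scatter), a larger shift than any step among the earlier compounds. Set against the fluoro group, the same chain gives an at least 4.7-fold higher number from compound 1 to compound 4 (0.67 log units; beyond the scatter), so compound 4 also stands above the compound that carries the smaller fluoro group.

Going by these compounds, whether the loss follows from the amine or from the added chain length stays open. The compounds shown include no plain ethoxy chain and no 2-hydroxyethoxy chain at this place that could separate the two.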